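This account rests on a few compounds, and the source may have more. Where it says the series, first, only, none or still open, it means among the compounds named here.

Measured compounds:
compound 1 `Cc1oc2c3c(ccc2c(=O)c1C)OC[C@H]1[C@@H]3c2c(ccc(C(=O)c3ccccc3)c2O)OC1(C)C`, > 100000 nM
compound 2 `Cc1coc2c3c(ccc2c1=O)OC[C@H]1[C@@H]3c2c(ccc(C(=O)c3ccccc3)c2O)OC1(C)C`, 1500 nM
compound 3 `Cc1oc2c3c(ccc2c(=O)c1C)OC[C@H]1[C@@H]3c2ccc3ccccc3c2OC1(C)C`, > 100000 nM

In a functional assay on HeLa cells (Homo sapiens) for cytotoxicity, read by MTT assay (a higher number here means a weaker inhibitor, a lower number a stronger inhibitor), compound 1 reaches only a limit of the assay, > 100000 nM. In this assay compound 2 gives 1500 nM. The change between them is hydrogen in place of methyl on an aromatic carbon, and it gives an at least 66-fold lower number from compound 1 to compound 2 (1.82 log units; beyond the scatter). The size of that step is bounded from one side only, which rests on (the limit of > 100000 nM in this assay, at which 2 of the 3 values shown sit).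

Compound 3 is built on a different core; the difference between the two cores is not broken down here. In this assay compound 3 sits at a limit of the assay as well, > 100000 nM.

Compound 4 `Cc1coc2c3c(ccc2c1=O)OC[C@H]1[C@@H]3c2ccc3ccccc3c2OC1(C)C` is not yet measured. It stands to compound 3 as compound 2 stands to compound 1: hydrogen in place of methyl on an aromatic carbon. The surroundings are not identical, since in compound 3 the ring carrying the change is part of a fused or bridged system of six rings, whereas in compound 1 it is part of a fused or bridged system of five rings, so this is the same kind of change, not the same change.

For compound 4 in this assay a step of about an at least 16-fold lower number from compound 3 to compound 4 (1.22 log units; beyond the scatter) is expected, on the strength of the step from compound 1 to compound 2, an at least 66-fold lower number from compound 1 to compound 2 (1.82 log units; beyond the scatter), with wide uncertainty because compound 3 only sets a limit, > 100000 nM. The estimate for compound 4 is 6000 nM, between 800 nM and 100000 nM.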

Compound 4, half-maximal inhibitory concentration: > 100000 nM
Compound 4 gave a limit, no number (the forecaster's own chance of this, stated with the estimate: 35%); middle value at least 16-fold (1.22 log units) away from the limit.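

In this assay compound 3 and compound 4 both sit at a limit of the assay, so no step can be read between them, because the only thing the two results give is that shared limit: the limit of > 100000 nM in this assay, at which 3 of the 4 values shown sit.

The compounds shown leave open whether hydrogen in place of methyl on an aromatic carbon changes the cytotoxicity read-out at all on the core of compound 3.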